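This account rests on a few compounds, and the source may have more. Where it says the series, first, only, none or still open, it means among the compounds named here.

Measured compounds in an ADME assay on J774 cells (Mus musculus) for cytotoxicity; a higher number here means that more compound is needed for the effect, a lower number that less compound is needed:

Compound 1 `CCCCc1ccc2[nH]cc(C(=O)OC)c(=O)c2c1` gives > 20000 nM, which is a limit of the assay and not a number.
Compound 2 `CCc1ccc2[nH]cc(C(=O)OC)c(=O)c2c1` gives > 20000 nM, likewise a limit of the assay.
Compound 3 `CCCc1cc2c(=O)c(C(=O)OC)c[nH]c2cc1OCCOc1ccccc1` gives > 20000 nM, again a limit of the assay.

Compound 1 and compound 2 share one core, and compound 1 differs from compound 2 by ethyl in place of hydrogen on a saturated chain carbon, two bonds along the chain from an aromatic carbon. In this assay the step that the two limits leave unreadable from compound 2 to compound 1 cannot be read, since both values are limits. Compound 3 rests on another core; the difference between the two cores is not broken down here.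

Compound 4 `CCCCCc1cc2c(=O)c(C(=O)OC)c[nH]c2cc1OCCOc1ccccc1` has not yet been measured. It differs from compound 3 by ethyl in place of hydrogen on a saturated chain carbon, three bonds along the chain from an aromatic carbon. This is the same kind of change as that from compound 2 to compound 1, but the place is not the same word for word: there the entering ethyl sits two bonds along the chain from an aromatic carbon, here three bonds along the chain from an aromatic carbon.

Within the data shown here, because of the limit of > 20000 nM in this assay, at which 3 of the 3 values shown sit, no measured step gives a readable size, and the step from compound 3 to compound 4 is expected to be a step that the limit leaves unreadable from compound 3 to compound 4. The estimate for compound 4 in this assay is 30000 nM, expected between 15000 nM and 80000 nM.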

Compound 4, half-maximal effective concentration: > 20000 nM
Compound 4: a limit, no number (the forecaster's own chance of this, stated with the estimate: 80%); the middle value lies beyond the limit too.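

The step from compound 3 to compound 4 in this assay cannot be read, and neither can the step from compound 2 to compound 1, since each of these values is a limit and not a number: the limit of > 20000 nM in this assay, at which 4 of the 4 values shown sit. The compounds shown leave open at what concentration any of them would reach the half-maximal effect, and whether adding ethyl to the chain changes that concentration.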